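Methylcarbamoyl Variant of an Inactive Sulfonamide

The source may report more compounds than this note shows. Statements on the series, on what has been measured and on what is new or still open speak of the compounds shown alone.

Compound 1 `COC(=O)c1cncc(NS(=O)(=O)c2cc(Cl)ccc2OC)c1` was examined in an assay on isolated protein for inhibition of alkaline phosphatase, tissue-nonspecific isozyme (Homo sapiens); on this read-out lower numbers stand for stronger inhibition and higher numbers for weaker inhibition. In this assay compound 1 gives > 20000 nM, which is a limit of the assay and not a number. Compound 1 therefore stands at the limit of > 20000 nM in this assay, at which 1 of the 2 values shown sits. For compound 2 `COC(=O)c1ccc(OC)c(S(=O)(=O)Nc2cccnc2)c1` this assay reports "not determined" (no result reported). Compound 3 `CNC(=O)c1cncc(NS(=O)(=O)c2cc(Cl)ccc2OC)c1` differs from compound 1 by methylamino in place of methoxy on a carbonyl carbon. Going by the values given here, no measured step between known compounds is available to lean on, so the estimated step that the limit leaves unreadable from compound 1 to compound 3 is expected to be none beyond the scatter. Compound 3 is accordingly estimated at 30000 nM, with a range from 5000 nM to 200000 nM.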

Compound 3, half-maximal inhibitory concentration: > 20000 nM
Compound 3 ended at the assay's limit; the forecaster's own chance of this, stated with the estimate: 80%; the middle value lies beyond the limit too.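

Going by these compounds alone, compound 1 and compound 3 each give only a limit, and no step between them can be read. The compounds shown leave open whether methylcarbamoyl in place of methoxycarbonyl changes inhibition at all, and which changes to the shared core would give a measurable value.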